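This account rests on a few compounds, and the source may have more. Where it says the series, first, only, none or still open, it means among the compounds named here.

Measured in a functional assay on A549 cells (Homo sapiens) for cytotoxicity, read by MTT assay, with a stated time of 48 h; a higher number here means a weaker inhibitor, a lower number a stronger inhibitor:
- compound 1 `N#Cc1ccc(Cn2c(/C=C3\SC(=S)N(CC(=O)O)C3=O)nc3ccccc32)cc1`: 26600 nM
- compound 2 `O=C(O)CN1C(=O)/C(=C/c2nc3ccccc3n2Cc2ccc([N+](=O)[O-])cc2)SC1=S`: 11400 nM
- compound 3 `O=C(O)CN1C(=O)/C(=C/c2nc3ccccc3n2Cc2ccccc2F)SC1=S`: 2670 nM

Compound 1 has the highest number of the three, which makes it the weakest inhibitor of the set. Its nearest neighbour is reached by a 2.3-fold lower number from compound 1 to compound 2 (0.37 log units; beyond the scatter), and the furthest by a 10-fold lower number from compound 1 to compound 3 (1.00 log units; beyond the scatter).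

The step followed here leads to compound 4 `O=C(O)CN1C(=O)/C(=C/c2nc3ccccc3n2Cc2ccc(F)cc2F)SC1=S`, and the change is 2,4-difluorophenyl in place of 4-cyanophenyl on a saturated chain carbon bound to an aromatic nitrogen. In words, 2,4-difluorophenyl stands in place of 4-cyanophenyl on a saturated chain carbon bound to an aromatic nitrogen.

Among the compounds with values here, the closest precedent is a 10-fold lower number from compound 1 to compound 3 (1.00 log units; beyond the scatter), where 4-cyanophenyl also leaves and 2-fluorophenyl enters. The comparison a 4.3-fold lower number from compound 2 to compound 3 (0.63 log units; beyond the scatter) points the same way, with 2-fluorophenyl again giving the lower number. The step of a 2.3-fold lower number from compound 1 to compound 2 (0.37 log units; beyond the scatter) bears less directly, since no fluorine enters there. Within the data shown here, no measured compound carries the second fluorine of compound 4, so its contribution remains open and the range must stay wide.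

A drop of about the size seen for the single-fluorine swap is therefore expected in this assay, and the expected step is an 8.9-fold lower number from compound 1 to compound 4 (0.95 log units; beyond the scatter). The estimate for compound 4 is 3000 nM, with an expected range from 1000 nM to 9000 nM.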

Compound 4, half-maximal inhibitory concentration: 12800 nM
Beside the measured number, compound 4's estimate is 4.3-fold (0.63 log units) below it; measured number above the stated range.
By their numbers in this assay, from the lowest: compound 3; then compounds 2 and 4 (each within the scatter of the next); then compound 1.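

In this assay, within the data shown here, the second fluorine matters more than the earlier compounds could suggest: fluoro in place of hydrogen on an aromatic carbon gives a 4.8-fold higher number from compound 3 to compound 4 (0.68 log units; beyond the scatter), so compound 3 keeps its lead and adding fluorine does not by itself lower the number. The 2,4-difluorophenyl group still improves on 4-cyanophenyl at this saturated chain carbon bound to an aromatic nitrogen, with a 2.1-fold lower number from compound 1 to compound 4 (0.32 log units; beyond the scatter), but it cannot be told apart from 4-nitrophenyl, given a 1.1-fold higher number from compound 2 to compound 4 (0.05 log units; within the scatter). Nothing measured on these compounds accounts for the loss that comes with the added fluorine.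

The compounds shown leave open whether a lone fluorine in the place of the added one, as in 4-fluorobenzyl, would give a number like that of compound 3 or like that of compound 4, and whether a chloro or methoxy group there would behave as fluoro does. They also leave open how far these steps hold when the carboxylic acid of the shared core gives way to a methyl ester or a primary amide.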